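The source may hold more compounds than are shown below. What is called first, only, known or untested is meant among the compounds shown, and "the series" means these compounds.

Compound 1 `Nc1oncc1-c1ccccc1`: 85 nM
Compound 2 `NC(=O)c1oncc1-c1ccccc1`: > 25000 nM, a limit of the assay
Compound 3 `CNC(=O)c1oncc1-c1ccccc1`: > 25000 nM, a limit of the assay

In an assay on SW48 cells for inhibition of Tryptophan 2,3-dioxygenase (Homo sapiens), read by fluorescence, with a stated time of 30 min (on this read-out higher numbers stand for an effect only at larger amounts of compound and lower numbers for an effect already at smaller amounts), compound 1 gives 85 nM. For compound 2 the assay reports only the limit > 25000 nM. For compound 3 it likewise reports only the limit > 25000 nM, so compound 3 stands at the limit of > 25000 nM in this assay, at which 2 of the 3 values shown sit, with no number of its own. Compound 4 `OCc1oncc1-c1ccccc1` differs from compound 3 by hydroxymethyl in place of methylcarbamoyl on an aromatic carbon. The measured steps that bear on this change are an at least 290-fold higher number from compound 1 to compound 3 (2.46 log units; beyond the scatter) and an at least 290-fold higher number from compound 1 to compound 2 (2.46 log units; beyond the scatter), while a step that the two limits leave unreadable from compound 2 to compound 3. Since compound 3 sits at a limit, the step to compound 4 cannot be read against a number. The estimate below therefore rests on compound 1 alone, whose value is 85 nM. A step toward lower numbers is expected for compound 4, namely an at least 6.2-fold lower number from compound 3 to compound 4 (0.79 log units; beyond the scatter). Compound 4 is therefore estimated at 4000 nM, within a range from 400 nM to 25000 nM.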

Compound 4, half-maximal effective concentration: 18000 nM
Estimate against measurement, compound 4: 4.5-fold (0.65 log units) below; low and high end bracket the measured number.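

In this assay hydroxymethyl on this aromatic carbon gives a number rather than a limit, yet the change from amino still costs heavily, with a 210-fold higher number from compound 1 to compound 4 (2.33 log units; beyond the scatter) on record. Against the two amides the steps read an at least 1.3-fold lower number from compound 3 to compound 4 (0.14 log units; that floor lies within the scatter) and an at least 1.3-fold lower number from compound 2 to compound 4 (0.14 log units; that floor lies within the scatter) and, with both floors within the scatter, show no firm gain. Amino alone among the four groups shown holds this position at a low number, and replacing the amide with hydroxymethyl does not bring that back. Open, from the compounds shown here alone, is whether the nitrogen must sit directly on the ring, which aminomethyl would test, and whether methylamino or dimethylamino would match amino.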